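A few compounds are considered here, and "the series" means these few. Any claim that something is new, unique, unknown or untested is made for them only; others in the source may bear on it.

Compounds measured:
compound 1, `Cc1nc(NCCNS(C)(=O)=O)nc2ccc(NC(=O)/C=C/c3ccc(OC(F)(F)F)cc3)cc12`: 169 nM
compound 2, `Cc1nc(N2CCC(N3CCCC3=O)CC2)nc2ccc(NC(=O)/C=C/c3ccc(Cl)cc3)cc12`: 74 nM

Two compounds with the shared core carry numbers in an assay on CHO-K1 cells for displacement of a labelled ligand from melanin-concentrating hormone receptor 1 (Homo sapiens), read by scintillation proximity assay, with a stated time of 2 h; a lower number here means a stronger inhibitor, a higher number a weaker inhibitor. Compound 1 gives 169 nM and stands highest of the two numbers. Its nearest neighbour, compound 2, gives 74 nM, a lower number that lies beyond the usual scatter, so compound 2 is the stronger inhibitor of the pair. Going by the values given here, no single-place step links these two, since they differ both at the aromatic carbon between two ring nitrogen atoms and on the cinnamamide ring.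

Compound 3, `Cc1nc(N2CCC(N3CCOC3=O)CC2)nc2ccc(NC(=O)/C=C/c3ccc(OC(F)(F)F)cc3)cc12`, has not yet been measured. It differs from compound 1 in one place: 4-(2-oxo-1,3-oxazolidin-3-yl)piperidin-1-yl in place of (2-(methanesulfonamido)ethyl)amino on an aromatic carbon. The group that enters is the kind of ring-bearing substituent that compound 2 carries at the same carbon, while the trifluoromethoxy side of compound 1 is kept. On that basis a step down in this assay is expected from compound 1 to compound 3, of roughly the size that separates compound 1 from compound 2, namely a 2.3-fold lower number from compound 1 to compound 3 (0.35 log units; beyond the scatter). Compound 3 is thus estimated at 75 nM in this assay, in a range from 30 nM to 190 nM.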

Compound 3, half-maximal inhibitory concentration: 41 nM
For compound 3 the middle estimate is 1.8-fold (0.26 log units) above the measured one; the range from low to high includes it.
By their numbers in this assay, from the lowest: compounds 3 and 2 (each within the scatter of the next); then compound 1.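

In this assay, going by these compounds alone, this is the first single-place reading at the aromatic carbon between two ring nitrogen atoms: with the trifluoromethoxy side held constant, placing 4-(2-oxo-1,3-oxazolidin-3-yl)piperidin-1-yl on that carbon in place of (2-(methanesulfonamido)ethyl)amino gives a 4.1-fold lower number from compound 1 to compound 3 (0.62 log units; beyond the scatter). The position therefore accepts a group of 12 heavy atoms with two non-aromatic rings and no hydrogen-bond donors in place of an open chain of 8 heavy atoms with 2 donors, and the number still falls beyond the scatter. Size, ring content and donor count all change in this one step, and nothing available here separates their contributions or explains the result.

The compounds shown leave open whether the step belongs to the piperidine ring or to the 2-oxo-1,3-oxazolidin-3-yl group it carries, a question that a plain piperidin-1-yl or a 4-aminopiperidin-1-yl group on the same carbon would address. They also leave open whether the same exchange gives a step of similar size when a chloro group replaces the trifluoromethoxy group on the cinnamamide ring.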